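Methoxy to hydroxy on a cytotoxicity series

The source may report more compounds than this note shows. Statements on the series, on what has been measured and on what is new or still open speak of the compounds shown alone.

Of the compounds shown here, two of one series have been measured in a functional assay on 786-0 cells (Homo sapiens) for cytotoxicity, read by sulforhodamine B assay, with a stated time of 48 h, tested at 0.001 uM; a higher number here means a weaker effect of the compound at the concentration tested, a lower number a stronger effect. Compound 1 `Cc1cc(O)cc(-c2nn(CC#N)cc2-c2ccnc(-c3ccc(Oc4ccccc4)cc3)c2)c1` gives 98% in this assay. Compound 2 `COc1cc(C)cc(-c2nn(CC#N)cc2-c2ccnc(-c3ccc(N(C)C)cc3)c2)c1` gives 101% in this assay, the higher of the two numbers, though its nearest neighbour, compound 1, sits within the usual scatter of it, so the two compounds cannot be ranked against each other; both show that little of the cells' growth is held back at this concentration.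

Compound 3 `Cc1cc(O)cc(-c2nn(CC#N)cc2-c2ccnc(-c3ccc(N(C)C)cc3)c2)c1` has not yet been measured. It differs from compound 2 in one place: hydrogen in place of methyl on an oxygen on an aromatic ring. With no measured step of this kind in the series, the size of the change can only be guessed. Since both measured compounds cluster near the top of the scale, compound 3 is expected to follow them, with a step of about a number 2 percentage points lower from compound 2 to compound 3 (within the scatter) in this assay, one not expected to go beyond the scatter in either direction. The estimate for compound 3 in this assay is 99%, within a range from 90% to 108%.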

Compound 3, a percentage reported as activity, at one concentration (the size of the read-out at that concentration, not a potency): 102%
The estimate for compound 3 lay 3 percentage points below the measured number, within the range that was stated.
By their numbers in this assay, from the lowest: compounds 1, 2 and 3 (each within the scatter of the next).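

In this assay, within the data shown here, the exchange of methoxy for hydroxy on the 3-methoxy-5-methylphenyl group, the first such pair, reads as a number 1 percentage points higher from compound 2 to compound 3 (within the scatter) and so gives no readable difference at this position, at this single concentration. The second pair keeps the hydroxy group and places dimethylamino where phenoxy stood on an aromatic carbon, and it reads as a number 4 percentage points higher from compound 1 to compound 3 (within the scatter) in this assay with the same outcome, so neither of the two changes separates the compounds here. Nothing in the information at hand bears on why these compounds read alike.

A reading this close to the top of the scale cannot show whether methoxy and hydroxy, or phenoxy and dimethylamino, would part at concentrations where the cells' growth is actually held back. It also leaves open what a larger group on that oxygen, such as ethoxy or benzyloxy, would do, or an amine or a carboxylic acid taking the place of the hydroxy group on the same ring.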